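Nitro for trifluoromethyl on a benzyl ether

The source may hold more compounds than are shown below. What is called first, only, known or untested is meant among the compounds shown, and "the series" means these compounds.

Compound 3 `FC(F)(F)c1ccc(COc2ccccc2Nc2ncnc3cc4c(cc23)OCCOCCO4)cc1` stands at a limit of the assay: in a functional assay on MCF7 cells (Homo sapiens) for antiproliferative activity, read by MTT assay, with a stated time of 72 h (on this read-out higher numbers stand for weaker inhibition and lower numbers for stronger inhibition), compound 3 gives > 100000 nM, a limit and not a number. Compound 1 `c1ccc(COc2ccccc2Nc2ncnc3cc4c(cc23)OCCOCCO4)cc1` likewise gives > 100000 nM, also a limit. Compound 2 `c1ccc(COc2ccc(Nc3ncnc4cc5c(cc34)OCCOCCOCCO5)cc2)cc1`, built on its own core, gives 8340 nM. Among the measured compounds shown here, the only measured step toward compound 3, a step that the two limits leave unreadable from compound 1 to compound 3, cannot be sized, since both of its ends rest at the limit of > 100000 nM in this assay, at which 2 of the 3 values shown sit. Compound 4 `O=[N+]([O-])c1ccc(COc2ccccc2Nc2ncnc3cc4c(cc23)OCCOCCO4)cc1` differs from compound 3 by nitro in place of trifluoromethyl on an aromatic carbon. For the measured compounds named here, no measured step bears directly on this change, so the step of a number no higher from compound 3 to compound 4 (the limit leaves the size open) is expected to stay within the scatter. Compound 4 is therefore estimated at 100000 nM, within 30000 nM to 300000 nM, and is most likely reported again only as a limit.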

Compound 4, half-maximal inhibitory concentration: > 100000 nM
Compound 4: a limit, no number (the forecaster's own chance of this, stated with the estimate: 75%); the middle value sits exactly at the limit.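

Among the compounds shown here, no step among compound 1, compound 3 and compound 4 can be read, since each rests at a limit and not a number: the limit of > 100000 nM in this assay, at which 3 of the 4 values shown sit.

The compounds shown leave open whether hydrogen, trifluoromethyl and nitro on this aromatic carbon differ at all.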